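The source may report more compounds than this note shows. Statements on the series, on what has been measured and on what is new or still open speak of the compounds shown alone.

Going by the values given here, compound 2 `CCCc1ccc2c(c1)c(=O)c(C(=O)Nc1ccc(Oc3ncnc4[nH]cc(-c5ccccc5)c34)c(F)c1)c(C)n2C` gives 61 nM in an assay on isolated protein for inhibition of tyrosine-protein kinase receptor UFO (Homo sapiens), read by FRET and Z'-LYTE, with a stated time of 1.5 h (on this read-out lower numbers stand for stronger inhibition and higher numbers for weaker inhibition), the lower of the two numbers measured so far; the only other compound, compound 1 `Cc1ccc2c(c1)c(=O)c(C(=O)Nc1ccc(Oc3ncnc4[nH]cc(-c5ccccc5)c34)c(F)c1)c(C)n2C`, gives 100 nM, and the two lie within the scatter of each other. The move from compound 2 to compound 3 `Cc1c(C(=O)Nc2ccc(Oc3ncnc4[nH]cc(-c5ccccc5)c34)c(F)c2)c(=O)c2cc(C(C)(C)C)ccc2n1C` replaces one group on the core: tert-butyl in place of propyl on an aromatic carbon. Among the compounds with values here, the only measured step that bears on this position is a 1.6-fold lower number from compound 1 to compound 2 (0.21 log units; within the scatter), which lengthened the chain on the same aromatic carbon without moving the number beyond the scatter. Growing the chain further into tert-butyl therefore has no measured precedent pointing to a change in either direction, and the expectation is for no step beyond the scatter. For compound 3 the estimated value is 65 nM, with a range from 25 nM to 170 nM, meaning an expected step of a 1.1-fold higher number from compound 2 to compound 3 (0.03 log units; within the scatter).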

Compound 3, half-maximal inhibitory concentration: 42 nM
Compound 3: the middle estimate sits 1.5-fold (0.19 log units) above what was measured; the measured number falls inside the stated range.
By their numbers in this assay, from the lowest: compounds 3, 2 and 1 (each within the scatter of the next, the first and the last beyond it).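

In this assay, going by these compounds alone, tert-butyl in place of methyl on this aromatic carbon gives a 2.4-fold lower number from compound 1 to compound 3 (0.38 log units; beyond the scatter) and is the first step at this position to lie beyond the scatter. Set against propyl, the same group gives a 1.5-fold lower number from compound 2 to compound 3 (0.16 log units; within the scatter) so the branched group and the straight chain cannot be told apart, and only the comparison with methyl separates the compounds. Nothing at hand offers an explanation for the step from methyl to tert-butyl.

On these data alone, only these three alkyl groups appear at this position, so it remains open whether a longer chain, a methoxy group, an amine or a carboxylic acid there would keep the number or shift it. As far as these compounds go, the rest of the molecule is identical across compounds 1, 2 and 3, so it also remains open whether the step from methyl to tert-butyl would hold on a changed core.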